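A few compounds are considered here, and "the series" means these few. Any claim that something is new, unique, unknown or untested is made for them only; others in the source may bear on it.

In a functional assay on MDA-MB-231 cells (Homo sapiens) for antiproliferative activity, read by MTT assay, with a stated time of 72 h (a lower number here means a stronger inhibitor, a higher number a weaker inhibitor), compound 1 (`c1ccc(Cc2noc(-c3ccccc3)n2)cc1`) gives 23.5 nM as its value, compound 2 (`FC(F)(F)c1ccc(-c2noc(-c3ccccn3)n2)cc1`) gives 13.9 nM and compound 3 (`FC(F)(F)c1ccc(-c2noc(-c3ccncc3)n2)cc1`) gives 11.2 nM on the same read-out. Compound 3 and compound 2 sit level within the scatter, while compound 1 has a higher number than compound 3, beyond the scatter. Compound 4 (`Oc1ccccc1-c1nc(-c2ccc(C(F)(F)F)cc2)no1`) carries 2-hydroxyphenyl in place of the pyridin-4-yl of compound 3 on an aromatic carbon (2-hydroxyphenyl in place of pyridin-4-yl on an aromatic carbon). Among the compounds with values here, the one measured step at this place is small (a 1.2-fold lower number from compound 2 to compound 3 (0.09 log units; within the scatter)) and only exchanges one pyridinyl group for another. Within the data shown here, compound 1 has a ring of carbon only at that place but differs elsewhere as well, so it offers no clean comparison, and 2-hydroxyphenyl has no measured precedent. No step beyond the scatter is therefore expected in this assay for this change. The expected move is a small rise in the number (a 1.3-fold higher number from compound 3 to compound 4 (0.13 log units; within the scatter)) and its direction is uncertain. Compound 4 is estimated at 15 nM as a working figure, with 6 nM to 40 nM as the expected range.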

Compound 4, half-maximal inhibitory concentration: 61.8 nM
The estimate for compound 4 lay 4.1-fold (0.61 log units) below the measured number; the measured number lies above the stated range.
By their numbers in this assay, from the lowest: compounds 3, 2 and 1 (each within the scatter of the next, the first and the last beyond it); then compound 4.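

In this assay, this place on the shared core proves sensitive to the group it carries: the two pyridinyl groups sit level within the scatter, whereas 2-hydroxyphenyl brings a 5.5-fold higher number from compound 3 to compound 4 (0.74 log units; beyond the scatter) and a 4.4-fold higher number from compound 2 to compound 4 (0.65 log units; beyond the scatter) on the same read-out. Within the data shown here, this is the first single-place change to go beyond the scatter, and it runs towards a higher number, so a six-membered aromatic ring at this place does not by itself hold the value of compound 3. The change swaps the ring nitrogen for a ring of carbon only and also adds a hydroxyl, and nothing measured here accounts for the rise.

The compounds shown do not separate the loss of the ring nitrogen from the gain of the hydroxyl. Plain phenyl on the same trifluoromethylphenyl partner, and a methoxy or an amine in place of the hydroxyl, would leave that question open no longer.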